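Swapping a side chain on a B-cell active compound

The source may report more compounds than this note shows. Statements on the series, on what has been measured and on what is new or still open speak of the compounds shown alone.

So far, three compounds sharing one core have been measured in a functional assay on the whole organism (B cells) with Mus musculus as the target; on this read-out higher numbers stand for larger maximal responses and lower numbers for smaller maximal responses. Compound 1, `C=CCn1c(=O)n(CCCCO)c2nc(N)nc(O)c21`, gives 12%. Compound 2, `NCC(O)Cn1c(=O)n(C2OC(CO)[C@@H](O)[C@H]2O)c2nc(N)nc(O)c21`, gives 110%. Compound 3, `C=CCN1C(=C(C(=O)OCC)C(=O)OCC)N([C@H]2OC(CO)[C@H]3OC(C)(C)O[C@H]32)c2cc(N)nc(O)c21`, gives 0%. Among these three numbers compound 2 stands highest: compound 1 lies well below it, by a gap beyond the usual scatter, and compound 3 lies further below still, again beyond the scatter.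

The next compound, compound 4, `CCOC(=O)Cn1c(=O)n(C2OC(CO)[C@@H](O)[C@H]2O)c2nc(N)nc(O)c21`, is built from compound 2 by one change: ethoxycarbonyl in place of 2-amino-1-hydroxyethyl on a saturated chain carbon bound to an aromatic nitrogen. The group that leaves carries hydrogen-bond donors, the group that enters carries none, and the change sits on a saturated chain carbon bound to an aromatic nitrogen, while the rest of compound 2 is kept.

Within the data shown here, no pair of measured compounds differs in just one place, so there is no directly comparable step to lean on. Compound 1 shows that a differently substituted core can give a small response, but it differs from compound 2 in more than one place. The step from compound 2 to compound 4 is therefore expected to be a decrease of uncertain size, a number 50 percentage points lower from compound 2 to compound 4 (beyond the scatter), rather than no change. Compound 4 is expected to give about 60% in this assay, in a range from 10% to 110%.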

Compound 4, largest response reached (reported as maximal response), in percent of the reference or control that the assay uses: 86%
Beside the measured number, compound 4's estimate is 26 percentage points below it, and the stated range covers the measured number.
By their numbers in this assay, from the lowest: compound 3; then compound 1; then compound 4; then compound 2.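

Among these compounds, compounds 2 and 4 are the first pair here that differ in one place only, so they give the first direct reading of a change on this saturated chain carbon bound to an aromatic nitrogen: in this assay, ethoxycarbonyl in place of 2-amino-1-hydroxyethyl gives a number 24 percentage points lower from compound 2 to compound 4 (beyond the scatter), a modest step. The response falls but is far from lost, since compound 4 still gives 86% although the entering group has no hydrogen-bond donors, so in this pair the 2-amino-1-hydroxyethyl group is not needed for a large maximal response. Nothing available explains why the number drops by this amount, and the size of the step is all that can be stated.

This single pair cannot tell whether the step comes from losing the amine, losing the hydroxyl or gaining the ester, and a carboxylic acid in place of ethoxycarbonyl, a simple 2-hydroxyethyl group or a longer chain at this carbon would help pull those apart. As far as these compounds go, whether the same swap would give a similar step on a differently substituted core also remains open.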